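Moving a Hydroxyl Group on a Pyridine Core

A few compounds are considered here, and "the series" means these few. Any claim that something is new, unique, unknown or untested is made for them only; others in the source may bear on it.

The measured compounds and their values are:

Compound 1, `Oc1cccc(-c2cc(-c3cccs3)cc(-c3cccc(O)c3)n2)c1`, gives 1630 nM in a functional assay on DU-145 cells (Homo sapiens) for cytotoxicity, read by CCK-8 assay; a lower number here means a stronger inhibitor, a higher number a weaker inhibitor.
Compound 2, `Oc1ccc(-c2cc(-c3cccs3)cc(-c3cccc(O)c3)n2)cc1`, gives 1890 nM.
Compound 3, `Oc1ccc(-c2cc(-c3cccnc3)cc(-c3cccc(O)c3)n2)cc1`, gives 6390 nM.

Compound 4, `Oc1ccc(-c2cc(-c3cccnc3)cc(-c3ccc(O)cc3)n2)cc1`, has not yet been measured. It differs from compound 3 in one place: 4-hydroxyphenyl in place of 3-hydroxyphenyl on an aromatic carbon. The same kind of change, (4-hydroxyphenyl in place of 3-hydroxyphenyl on an aromatic carbon), links compound 1 to compound 2, where the step was a 1.2-fold higher number from compound 1 to compound 2 (0.06 log units; within the scatter). The surroundings of the change differ between the two pairs: in the first pair the altered carbon sits meta to a 3-hydroxyphenyl group and meta to a thiophen-2-yl group, in the second pair meta to a 4-hydroxyphenyl group and meta to a pyridin-3-yl group. How the core of compound 1 differs from the core of compound 3 is not broken down here. Within the data shown here, the one other step that is known, a 3.4-fold higher number from compound 2 to compound 3 (0.53 log units; beyond the scatter), places compound 3 at the high end of the three values.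

Because the earlier step of a 1.2-fold higher number from compound 1 to compound 2 (0.06 log units; within the scatter) stayed within the scatter, compound 4 is expected to come out near compound 3, with an expected step of a 1.2-fold higher number from compound 3 to compound 4 (0.07 log units; within the scatter) in this assay. The estimate for compound 4 is 7500 nM, with a likely range from 3500 nM to 16000 nM.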

Compound 4, half-maximal inhibitory concentration: 240 nM
Beside the measured number, compound 4's estimate is 31-fold (1.49 log units) above it; the measured number lies below the stated range.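

Changing 3-hydroxyphenyl to 4-hydroxyphenyl on the shared pyridine-type ring produced a large gain in this assay, with a 27-fold lower number from compound 3 to compound 4 (1.43 log units; beyond the scatter). So the result of this change on one core did not predict its result on the other, and the near-absence of an effect in the first pair was no guide to the second: the same change on two cores in this assay, a 1.2-fold higher number (0.06 log units; within the scatter) from compound 1 to compound 2 and a 27-fold lower number (1.43 log units; beyond the scatter) from compound 3 to compound 4, 31-fold (1.49 log units) apart, beyond the scatter of two such steps This does not show which difference between the two cores matters, since they differ in two places: the first pair carries thiophen-2-yl and a 3-hydroxyphenyl group, while the second carries pyridin-3-yl and a 4-hydroxyphenyl group, and two pairs cannot establish a general rule for the series.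

The compounds shown leave open whether the large step depends on pyridin-3-yl, on the 4-hydroxyphenyl group already present, or on both together, and a compound with thiophen-2-yl and two 4-hydroxyphenyl groups would help to separate these possibilities. Also open, from the compounds shown here alone, is how a methoxy group or an amine in place of the hydroxyl would behave on either core, which would test whether the hydroxyl itself is needed for the number seen with compound 4.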